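Trifluoromethyl to Methyl and Cellular Antiproliferative Potency

This account rests on a few compounds, and the source may have more. Where it says the series, first, only, none or still open, it means among the compounds named here.

Compound 1 `Cc1ccccc1C(=O)Nc1sc2c(c1C(N)=O)CCN(C(=S)Nc1ccccc1C(F)(F)F)C2` and compound 2 `Cc1ccccc1NC(=S)N1CCc2c(sc(NC(=O)c3ccccc3C)c2C(N)=O)C1` differ by methyl in place of trifluoromethyl on an aromatic carbon. In a functional assay on HL-60 cells (Homo sapiens) for antiproliferative activity, with a stated time of 24 h (on this read-out lower numbers stand for stronger inhibition and higher numbers for weaker inhibition), compound 1 gives 23200 nM. Compound 2 reaches only the limit of the assay, > 50000 nM. The change produces an at least 2.1-fold higher number from compound 1 to compound 2 (0.33 log units; beyond the scatter), a step whose size is bounded by the limit of > 50000 nM in this assay, at which 1 of the 3 values shown sits.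

Compound 3 `NC(=O)c1c(NC(=O)c2ccc(C(F)(F)F)cc2)sc2c1CCN(C(=S)Nc1cc(C(F)(F)F)cc(C(F)(F)F)c1)C2` gives 16300 nM; how its core differs from the core of compound 1 is not broken down here. Compound 4 `Cc1ccc(C(=O)Nc2sc3c(c2C(N)=O)CCN(C(=S)Nc2cc(C(F)(F)F)cc(C(F)(F)F)c2)C3)cc1`, not yet measured, differs from compound 3 by methyl in place of trifluoromethyl on an aromatic carbon. This is the same kind of change as that between compound 1 and compound 2, but the place differs: there the group sits ortho to a large group, here para to a large group. A similar weakening is expected, a 2.1-fold higher number from compound 3 to compound 4 (0.33 log units; beyond the scatter), resting on an at least 2.1-fold higher number from compound 1 to compound 2 (0.33 log units; beyond the scatter). Compound 4 is therefore expected to give 35000 nM, with a range from 15000 nM to 80000 nM.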

Compound 4, half-maximal inhibitory concentration: 11800 nM
Compound 4: the middle estimate sits 3.0-fold (0.47 log units) above what was measured; measured number below the stated range.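

In this assay, methyl in place of trifluoromethyl gives a 1.4-fold lower number from compound 3 to compound 4 (0.14 log units; within the scatter), so this pair shows no change beyond the scatter. The same change therefore does not carry over with the same result from the core of compound 1 to the core of compound 3: the same change on two cores in this assay, an at least 2.1-fold higher number (0.33 log units; beyond the scatter) from compound 1 to compound 2 and a 1.4-fold lower number (0.14 log units; within the scatter) from compound 3 to compound 4, at least 2.9-fold (0.47 log units) apart, beyond the scatter of two such steps. For the compounds shown here, with only one pair on each core, the data do not show whether the core or the place of the group, para to a large group in compound 4, sets this gap, and the first step is open-ended: the limit of > 50000 nM in this assay, at which 1 of the 4 values shown sits.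

The compounds shown leave open how the change reads at one and the same place on both cores. They also leave open how a chlorine or a methoxy group at that aromatic carbon would compare in this assay.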